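Anilide para substituent: bromo to ethoxy in the series

This account rests on a few compounds, and the source may have more. Where it says the series, first, only, none or still open, it means among the compounds named here.

Compound 3 `COc1ccc(-c2nn(-c3ccccc3)cc2C(=O)Nc2ccc(Br)cc2)cc1` gives 5870 nM in a functional assay on HCT-116 cells (Homo sapiens) for cytotoxicity, read by MTT assay, with a stated time of 48 h (on this read-out lower numbers stand for stronger inhibition and higher numbers for weaker inhibition), the highest number among the three measured. Compound 1 `O=C(Nc1ccc(Br)cc1)c1cn(-c2ccccc2)nc1-c1ccccc1` gives 4470 nM; the step of a 1.3-fold higher number from compound 1 to compound 3 (0.12 log units; within the scatter) concerns the other phenyl and does not bear on the change below. Compound 2 `CCOc1ccc(NC(=O)c2cn(-c3ccccc3)nc2-c2ccc(C)cc2)cc1` gives 780 nM, but differs from compound 3 in two places, so its gap to compound 3 can only be read as a whole. Compound 4 `CCOc1ccc(NC(=O)c2cn(-c3ccccc3)nc2-c2ccc(OC)cc2)cc1` carries ethoxy in place of bromo on an aromatic carbon. Among the measured compounds shown here, no measured single step covers this change; the only hint is that compound 2, also carrying ethoxy at this position, gives a number well below compound 3. The step from compound 3 to compound 4 is therefore expected as a 3.9-fold lower number from compound 3 to compound 4 (0.59 log units; beyond the scatter), toward lower numbers. Compound 4 is estimated at 1500 nM, with a range from 600 nM to 4000 nM.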

Compound 4, half-maximal inhibitory concentration: 970 nM
Compound 4: the middle estimate sits 1.5-fold (0.19 log units) above what was measured; low and high end bracket the measured number.
By their numbers in this assay, from the lowest: compounds 2 and 4 (each within the scatter of the next); then compounds 1 and 3 (each within the scatter of the next).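

The change from 4-bromophenyl to 4-ethoxyphenyl now has a single measured step in this assay (a 6.1-fold lower number from compound 3 to compound 4 (0.78 log units; beyond the scatter)), so the gap hinted at by compound 2 is seen at this position with the rest of the molecule held constant. With ethoxy in place, methoxy in place of methyl on the other phenyl stays within the scatter (a 1.2-fold higher number from compound 2 to compound 4 (0.09 log units; within the scatter)), as hydrogen to methoxy does with bromo in place (a 1.3-fold higher number from compound 1 to compound 3 (0.12 log units; within the scatter)). Nothing available explains the step at this position.

As far as these compounds go, whether a methoxy, an amine or a longer alkoxy chain here would give a similar number remains open. So does the size of the bromo to ethoxy step with hydrogen or methyl on the other phenyl.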